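The source may hold more compounds than are shown below. What is called first, only, known or untested is meant among the compounds shown, and "the series" means these compounds.

Three compounds that share one core and differ only in the group on a saturated chain carbon bound to an oxygen on an aromatic ring have been measured in a functional assay on PC-12 cells (Rattus norvegicus) for inhibition, read by sulforhodamine B assay; on this read-out higher numbers stand for weaker inhibition and lower numbers for stronger inhibition. Compound 1 `O=C1NC(=O)C(Cc2ccc(OCC3CCCCC3)cc2)S1` gives 26000 nM and compound 3 `CCCOc1ccc(CC2SC(=O)NC2=O)cc1` gives 45000 nM, two numbers within the scatter of each other. Compound 2 `O=C1NC(=O)C(Cc2ccc(OCC3CCC3)cc2)S1` reaches only a limit of the assay, > 100000 nM.

Compound 4 `COc1ccc(CC2SC(=O)NC2=O)cc1` differs from compound 3 by hydrogen in place of ethyl at that same place, which turns propoxy to methoxy: hydrogen in place of ethyl on a saturated chain carbon bound to an oxygen on an aromatic ring.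

All three measured steps fall at this place. One of them, a 1.7-fold higher number from compound 1 to compound 3 (0.24 log units; within the scatter), stays within the scatter. The other two, an at least 3.8-fold higher number from compound 1 to compound 2 (0.58 log units; beyond the scatter) and an at least 2.2-fold lower number from compound 2 to compound 3 (0.34 log units; beyond the scatter), go beyond it, but both rest on the limit of compound 2. The numbers therefore show no steady order with the group, and compound 2 goes against any simple trend. On this evidence, only a small drift towards a higher number is expected in this assay, not a clear shift beyond the scatter. The expected step is a 1.3-fold higher number from compound 3 to compound 4 (0.12 log units; within the scatter). For compound 4 the estimated value is 60000 nM, with an expected range from 25000 nM to 140000 nM.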

Compound 4, half-maximal inhibitory concentration: > 100000 nM
Compound 4: only a limit was reported; the forecaster's own chance of this, stated with the estimate: 30%; middle value at least 1.6-fold (0.22 log units) away from the limit.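

In this assay compound 4 gives only a limit, > 100000 nM. Hydrogen in place of ethyl, which turns propoxy to methoxy, brings an at least 2.2-fold higher number from compound 3 to compound 4 (0.34 log units; beyond the scatter), and hydrogen in place of cyclohexyl brings an at least 3.8-fold higher number from compound 1 to compound 4 (0.58 log units; beyond the scatter): at this place, ethyl and cyclohexyl both give a readable number, while hydrogen does not, and compound 2, with its cyclobutyl, goes against any reading that simply having a larger group there is enough. The step from compound 2 to compound 4 cannot be read, because both compounds sit at the same limit: the limit of > 100000 nM in this assay, at which 2 of the 4 values shown sit.

As far as these compounds go, it remains open whether a longer chain such as butyl, or an amine or a carboxylic acid carried on the same saturated chain carbon, would give a readable number in this assay, and so whether the readable numbers of compound 1 and compound 3 are isolated cases or part of a wider range of groups. Also open, from the compounds shown here alone, is how compound 2 and compound 4 compare with each other, since neither has a readable number here.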